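Fluoro for Methoxy on a Weakly Growth-Inhibiting Core

A few compounds are considered here, and "the series" means these few. Any claim that something is new, unique, unknown or untested is made for them only; others in the source may bear on it.

Compound 1 `COc1ccccc1Oc1ccnc2ccsc12` has been tested in an ADME assay on PLP2 cells (Sus scrofa) for inhibition, read by sulforhodamine B assay, with a stated time of 48 h; a lower number here means a stronger inhibitor of growth, a higher number a weaker inhibitor of growth. For compound 1 only a limit is reported, > 125000 nM. Its companion compound 2 `COc1cccc(Oc2ccnc3ccsc23)c1` carries the methoxy group on a different aromatic carbon, and in this assay compound 2 gives 26700 nM. The evidence on the measured compounds amounts to the limit of > 125000 nM in this assay, at which 1 of the 2 values shown sits, so where compound 1 stands is known only as a bound, and nothing here tells how far its true value lies from that of compound 2.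

Compound 3 `Fc1ccccc1Oc1ccnc2ccsc12` differs from compound 1 in one place: fluoro in place of methoxy on an aromatic carbon. Among the compounds with values here, no measured pair shows what this exchange does in this assay. Because compound 1 sits at the limit of > 125000 nM in this assay, at which 1 of the 2 values shown sits, the step from compound 1 to compound 3 is expected to be small, an at least 1.2-fold lower number from compound 1 to compound 3 (0.09 log units; that floor lies within the scatter), with no direction claimed beyond the scatter. Compound 3 is therefore estimated to give about 100000 nM in this assay, most likely between 30000 nM and 300000 nM, with a real chance that only a limit is again reported.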

Compound 3, concentration for 50% growth inhibition: 87200 nM
The estimate for compound 3 lay 1.1-fold (0.06 log units) above the measured number; the range from low to high includes it.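

Compound 3 gives a measured number in this assay, so this place on the ring, ortho to a large group, now has a real reading, which the methoxy group of compound 1 did not provide. Within the data shown here, the exchange of methoxy for fluoro also gains its first measured step, an at least 1.4-fold lower number from compound 1 to compound 3 (0.15 log units; that floor lies within the scatter), and this is the only information on the change so far. The printed figure is a floor and not the true size of the step, because compound 1 is known only as a limit: the limit of > 125000 nM in this assay, at which 1 of the 3 values shown sits.

The compounds shown leave open how large the step really is, and whether the same exchange would behave alike on the different aromatic carbon that carries the methoxy group in compound 2. They also leave open what other groups on this carbon of the shared core, such as an amine, a carboxylic acid or a longer chain, would do in this assay.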